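A few compounds are considered here, and "the series" means these few. Any claim that something is new, unique, unknown or untested is made for them only; others in the source may bear on it.

Compounds measured in a functional assay on MCF7 cells (Homo sapiens) for antiproliferative activity, read by MTT assay, with a stated time of 48 h; on this read-out higher numbers stand for weaker inhibition and lower numbers for stronger inhibition:
compound 1, `COc1ncc(-c2ccc3nc(NC(C)=O)nn3c2)cc1NS(=O)(=O)c1ccc(F)cc1`, 840 nM;
compound 2, `CCOCCNc1nc2ccc(-c3cnc(OC)c(NS(=O)(=O)c4ccc(F)cc4)c3)cn2n1`, 1350 nM;
compound 3, `CCOC(=O)CNc1nc2ccc(-c3cnc(OC)c(NS(=O)(=O)c4ccc(F)cc4)c3)cn2n1`, 4410 nM.

Compound 3 gives the highest number of the three: a 5.3-fold higher number from compound 1 to compound 3 (0.72 log units; beyond the scatter) and a 3.3-fold higher number from compound 2 to compound 3 (0.51 log units; beyond the scatter) both lie beyond the scatter, so compound 3 is the weakest of the measured set. Compound 4, `CNC(=O)CNc1nc2ccc(-c3cnc(OC)c(NS(=O)(=O)c4ccc(F)cc4)c3)cn2n1`, follows from compound 3 by methylamino in place of ethoxy on a carbonyl carbon. Among the measured compounds shown here, no measured step alters the carbonyl partner in this way; a 3.3-fold higher number from compound 2 to compound 3 (0.51 log units; beyond the scatter) concerns the chain carbon itself, and a 1.6-fold higher number from compound 1 to compound 2 (0.21 log units; within the scatter) stayed within the scatter. For the measured compounds named here, the data therefore give no direction for the step to compound 4, and the expected step of a 1.5-fold lower number from compound 3 to compound 4 (0.17 log units; within the scatter) is small. Compound 4 is estimated at 3000 nM, in a range of 1000 nM to 9000 nM, in this assay.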

Compound 4, half-maximal inhibitory concentration: 2540 nM
Compound 4: the middle estimate sits 1.2-fold (0.07 log units) above what was measured; the measured number falls inside the stated range.
By their numbers in this assay, from the lowest: compounds 1, 2, 4 and 3 (each within the scatter of the next, the first and the last beyond it).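

In this assay, among the compounds shown here, methylamino in place of ethoxy on the carbonyl carbon gives a 1.7-fold lower number from compound 3 to compound 4 (0.24 log units; within the scatter), so this change, which no earlier step covered, does not separate the ethoxycarbonyl and methylcarbamoyl groups. The methylcarbamoyl group also cannot be told apart from the ethoxymethyl group on the saturated chain carbon, with a 1.9-fold higher number from compound 2 to compound 4 (0.27 log units; within the scatter). Only the comparison with the acetyl group, a 3.0-fold higher number from compound 1 to compound 4 (0.48 log units; beyond the scatter), lies beyond the scatter, as it does for the (ethoxycarbonyl)methyl group of compound 3.

Going by these compounds, whether a carboxylic acid, a morpholine amide or a longer chain on this carbonyl carbon would give a clearly different number remains open. Nothing available bears on what lies behind these steps.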